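The compounds below may be only part of what the source reports. "The series", "measured", "known", "first", "only" and "open" are said of these compounds alone.

In a physicochemical assay for solubility, with a stated time of 24 h, at pH 2.2 (on this read-out lower numbers stand for lower solubility and higher numbers for higher solubility), compound 3 `CN(C)C(=O)c1cn(C)c2ccccc12` gives > 51 ug/mL, which is a limit and not a number. Compound 1 `CN(C)C(=O)c1c[nH]c2ccccc12` gives > 47 ug/mL, also a limit. Compound 2 `COC(=O)c1ccc2c(C(=O)Nc3ccccc3)cn(C)c2c1` gives < 1 ug/mL, again a limit, so every value in hand is of this kind. Compound 4 `COC(=O)c1ccc2c(C(=O)N(C)C)cn(C)c2c1`, not yet measured, differs from compound 3 by methoxycarbonyl in place of hydrogen on an aromatic carbon. Among the measured compounds shown here, the only measured step between compounds differing in one place is a step that the two limits leave unreadable from compound 1 to compound 3, for methyl in place of hydrogen on an aromatic nitrogen. It concerns another group and offers no size to carry over. The nearest guide is compound 2, which also holds a methoxycarbonyl but has a different amide, whereas compound 4 keeps the amide of compound 3. With compound 2 at < 1 ug/mL, a limit, a downward move is expected in this assay, though a far smaller fall than that limit alone might suggest, and the basis for its size is thin. The expected change is an at least 1.7-fold lower number from compound 3 to compound 4 (0.23 log units; that floor lies within the scatter), which is an estimate. For compound 4 the estimated solubility is 30 ug/mL, with an expected range from 8 ug/mL to 65 ug/mL.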

Compound 4, solubility: 50 ug/mL
For compound 4 the middle estimate is 1.7-fold (0.22 log units) below the measured one; measured number inside the range.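

In this assay, among the compounds shown here, compound 4 gives the first reading for a methoxycarbonyl compound that is a number and not a limit, and the change at this aromatic carbon of the six-membered ring reads as an at least 1.0-fold lower number from compound 3 to compound 4 (0.00 log units; that floor lies within the scatter), so the data show no fall that can be told from scatter. That step has only a floor, for compound 3 gives > 51 ug/mL, which is a limit. With methoxycarbonyl held in place, dimethylamino in place of anilino on a carbonyl carbon gives an at least 50-fold higher number from compound 2 to compound 4 (1.69 log units; beyond the scatter), so among the compounds shown the low reading of compound 2 goes with the anilino amide and not with methoxycarbonyl alone.

As far as these compounds go, the true size of the step from hydrogen to methoxycarbonyl stays open, and the step between the two compounds that carry only limits cannot be read. Also open, from the compounds shown here alone, is whether a carboxylic acid or a primary amide on the same aromatic carbon would read as compound 4 does, and whether the anilino amide would stay as low on the core of compound 3 with hydrogen in place of methoxycarbonyl.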